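Urea aryl series: chloro added to the trifluoromethylphenyl

This account rests on a few compounds, and the source may have more. Where it says the series, first, only, none or still open, it means among the compounds named here.

Measured in a functional assay on LOX IMVI cells (Homo sapiens) for inhibition, read by sulforhodamine B assay, with a stated time of 48 h; a lower number here means a stronger inhibitor of growth, a higher number a weaker inhibitor of growth:
compound 1 `COc1cc(-c2nn(-c3cccc(NC(=O)Nc4ccc(Cl)c(Cl)c4)c3)cc2-c2ccncc2)ccc1Cl`: 2620 nM
compound 2 `COc1cc(-c2nn(-c3cccc(NC(=O)Nc4cccc(C(F)(F)F)c4)c3)cc2-c2ccncc2)ccc1Cl`: 1650 nM

Two compounds of the shared core have been run in this assay, and they differ only in the aryl group on the amide-type nitrogen of the urea. Among the measured compounds shown here, the one step between them, a 1.6-fold lower number from compound 1 to compound 2 (0.20 log units; within the scatter), is within the scatter, so compound 2 and compound 1 cannot be told apart on these numbers; compound 2 merely gives the lower of the two figures.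

Compound 3 `COc1cc(-c2nn(-c3cccc(NC(=O)Nc4ccc(Cl)c(C(F)(F)F)c4)c3)cc2-c2ccncc2)ccc1Cl` is not yet measured. It differs from compound 2 by chloro in place of hydrogen on an aromatic carbon, and its aryl group thus carries both substituents seen singly in compound 1 and compound 2. For the measured compounds named here, the only step that bears on this change, a 1.6-fold lower number from compound 1 to compound 2 (0.20 log units; within the scatter), was within the scatter, so no step beyond the scatter is expected in this assay in either direction. Compound 3 is therefore estimated at 1900 nM, in the range 700 nM to 5000 nM, which corresponds to an expected step of a 1.2-fold higher number from compound 2 to compound 3 (0.06 log units; within the scatter).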

Compound 3, concentration for total growth inhibition: 4610 nM
Beside the measured number, compound 3's estimate is 2.4-fold (0.38 log units) below it; the measured number falls inside the stated range.
By their numbers in this assay, from the lowest: compounds 2, 1 and 3 (each within the scatter of the next, the first and the last beyond it).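

In this assay, chloro in place of hydrogen on the aromatic carbon para to a large group and ortho to a trifluoromethyl group gives a 2.8-fold higher number from compound 2 to compound 3 (0.45 log units; beyond the scatter), a modest step towards weaker growth inhibition and the first in this series beyond the scatter, so the urea aryl group is shown to tolerate a change here with a readable loss when the trifluoromethyl group is held. Trifluoromethyl in place of chloro on an aromatic carbon, with the other chloro held, gives a 1.8-fold higher number from compound 1 to compound 3 (0.25 log units; within the scatter), so compound 1 and compound 3 cannot be told apart and this exchange shows no readable effect on the number. Nothing at hand indicates why the added chloro shifts the number.

On these data alone, whether this step belongs to chloro itself or to any substituent at this carbon remains open, and a fluoro, methyl or methoxy group or an amine there would separate those readings. As far as these compounds go, whether the step holds with a different group in place of the trifluoromethyl group, or in other cell lines, also remains open.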